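Adding a methyl to the saturated linker of compound 3

A few compounds are considered here, and "the series" means these few. Any claim that something is new, unique, unknown or untested is made for them only; others in the source may bear on it.

Measured compounds:
compound 1 `C[C@@H](NC(=O)/C=C/c1ccc(C(C)(C)C)cc1)c1ccc(NS(C)(=O)=O)cc1` gives 160 nM
compound 2 `C/C(=C\c1ccc(C(C)(C)C)cc1)C(=O)N[C@H](C)c1ccc(NS(C)(=O)=O)cc1` gives 46 nM
compound 3 `C[C@@H](NC(=O)CCc1ccc(C(C)(C)C)cc1)c1ccc(NS(C)(=O)=O)cc1` gives 240 nM

In an assay on cells for antagonist activity at transient receptor potential cation channel subfamily V member 1 (Rattus norvegicus), read by scintillation counting, with a stated time of 10 min, in the presence of a further agent that is not named here (on this read-out higher numbers stand for weaker inhibition and lower numbers for stronger inhibition), compound 3 shows the highest number of the three. Its number and that of compound 1 lie within the usual scatter of each other, so no order can be drawn between them. Compound 2 stands beyond the scatter at a clearly lower number than compound 3.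

Compound 4 `CC(Cc1ccc(C(C)(C)C)cc1)C(=O)N[C@H](C)c1ccc(NS(C)(=O)=O)cc1` is not yet measured. It differs from compound 3 by methyl in place of hydrogen on a saturated chain carbon bound to a carbonyl carbon and a saturated chain carbon, that is a methyl in place of hydrogen on a saturated chain carbon bound to a carbonyl carbon and a saturated chain carbon.

Among the measured compounds shown here, no step of this exact kind has been measured. Compound 2 carries a methyl on its unsaturated linker and gives 46 nM, which lies beyond the scatter below compound 1. For compound 4 a modest move toward a lower number is therefore expected, a 2.0-fold lower number from compound 3 to compound 4 (0.30 log units; within the scatter), although it may stay within the scatter. The expected value for compound 4 is 120 nM, with a range from 40 nM to 400 nM.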

Compound 4, half-maximal inhibitory concentration: 270 nM
For compound 4 the middle estimate is 2.3-fold (0.35 log units) below the measured one; the measured number falls inside the stated range.
By their numbers in this assay, from the lowest: compound 2; then compounds 1, 3 and 4 (each within the scatter of the next).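

Placing a methyl in place of hydrogen on a saturated chain carbon bound to a carbonyl carbon and a saturated chain carbon gives a 1.1-fold higher number from compound 3 to compound 4 (0.05 log units; within the scatter) in this assay and so stays within the usual scatter. At this position of the saturated linker, this single added carbon therefore brings no readable change in inhibition. No measured evidence here accounts for this result.

From the compounds shown here alone, whether an ethyl, a hydroxyl or an amine on this same carbon would shift the number remains open. So does whether the two mirror-image arrangements of the methyl-bearing carbon would give different numbers.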